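A few compounds are considered here, and "the series" means these few. Any claim that something is new, unique, unknown or untested is made for them only; others in the source may bear on it.

Compound 1 `O=C(Nc1nc2cc(Cl)ccc2s1)C1CC1`: > 50000 nM
Compound 2 `CC(C)(C)C(=O)Nc1nc2ccc(Cl)cc2s1`: > 50000 nM

In an ADME assay on H9c2 cells (Rattus norvegicus) for cytotoxicity (a lower number here means a stronger inhibitor, a higher number a weaker inhibitor), compound 1 gives > 50000 nM, which is a limit of the assay and not a number. Compound 2 gives > 50000 nM, which is also a limit and not a number. Compound 2 thus has no exact value and stands at the limit of > 50000 nM in this assay, at which 2 of the 2 values shown sit.

Compound 3 `O=C(CC1CC1)Nc1nc2ccc(Cl)cc2s1` puts cyclopropylmethyl in place of tert-butyl on a carbonyl carbon. Going by the values given here, no measured pair shows what this change does in this assay. Among the compounds with values here, the only guide is compound 2, at > 50000 nM, a limit, so no clear shift in either direction is expected. The estimated step of a number no higher from compound 2 to compound 3 (the limit leaves the size open) is expected to stay within the usual scatter. Compound 3 will most likely be reported as a limit too. For compound 3 the expected value is 50000 nM, with an estimated range from 25000 nM to 100000 nM.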

Compound 3, half-maximal inhibitory concentration: > 50000 nM
Compound 3: a limit, no number; the forecaster's own chance of this, stated with the estimate: 85%; the middle value lies on the limit itself.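

In this assay compound 3 gives > 50000 nM, which is a limit and not a number. Going by these compounds alone, compound 2 also stands at a limit, so no step from it to compound 3 can be read. The compounds shown leave open what concentration would actually reach half-maximal inhibition for any of them.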